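This account rests on a few compounds, and the source may have more. Where it says the series, first, only, none or still open, it means among the compounds named here.

Working notes on the series. Compound 1 `Cc1ccccc1-c1nn(-c2ccc(Cl)cc2)cc1CNCCN1CCN(C)CC1` and compound 2 `CCCN1CCC(CNCc2cn(-c3ccc([N+](=O)[O-])cc3)nc2-c2ccc(OC(F)(F)F)cc2)CC1` share a basic side chain on a five-membered core. In an ADME assay on Huh-7 cells (Homo sapiens) for cytotoxicity (a lower number here means that less compound is tolerated, a higher number that more compound is tolerated), compound 1 gives 17000 nM; compound 2 gives 18000 nM in this assay, and the two numbers sit within the scatter of each other. Compound 3 `Cc1ccc(-n2cc(CNCCN3CCN(C)CC3)c(-c3ccccc3C)n2)c(C)c1` is not yet measured; it differs from compound 1 by 2,4-dimethylphenyl in place of 4-chlorophenyl on an aromatic nitrogen. For the measured compounds named here, no comparable step between measured compounds exists, so no step beyond the scatter is expected from compound 1 to compound 3, and the expected step is a 1.1-fold lower number from compound 1 to compound 3 (0.05 log units; within the scatter). Compound 3 is estimated at 15000 nM in this assay, with a range from 7000 nM to 32000 nM.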

Compound 3, half-maximal cytotoxic concentration: > 20000 nM
Compound 3: only a limit was reported; the forecaster's own chance of this, stated with the estimate: 15%; middle value at least 1.3-fold (0.12 log units) away from the limit.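

For the compounds shown here, on the aromatic nitrogen, 2,4-dimethylphenyl in place of 4-chlorophenyl gives the first readable step at this position: an at least 1.1-fold higher number from compound 1 to compound 3 (0.07 log units; that floor lies within the scatter). Compound 3 stands only as a limit in this assay: the limit of > 20000 nM in this assay, at which 1 of the 3 values shown sits. The change therefore brings no lower number, but the true size of the step cannot be read, and its floor stays within the scatter.

As far as these compounds go, whether the two methyl groups or the loss of chlorine matters more stays open. A plain phenyl group on the same nitrogen would separate the two.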